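A Nitro-to-Fluoro Swap at Two Ring Positions

The compounds below may be only part of what the source reports. "The series", "measured", "known", "first", "only" and "open" are said of these compounds alone.

Four compounds share one core and differ in a single group on a six-membered aromatic ring of carbon only. Compound 1 `Cn1nnnc1SCC(=O)N/N=C/c1ccccc1[N+](=O)[O-]` carries a nitro group there, and compound 3 `Cn1nnnc1SCC(=O)N/N=C/c1ccccc1F` carries a fluoro group in its place. Compound 2 `Cn1nnnc1SCC(=O)N/N=C/c1cccc([N+](=O)[O-])c1` is built from the same atoms as compound 1, joined differently; the difference between the two cores is not broken down here. Compound 4 `Cn1nnnc1SCC(=O)N/N=C/c1cccc(F)c1` stands to compound 2 as compound 3 stands to compound 1.

All were run in a functional assay on A549 cells (Homo sapiens) for cytotoxicity, read by XTT assay, with a stated time of 24 h; a lower number here means a stronger inhibitor, a higher number a weaker inhibitor. In this assay compound 1 gives 1600000 nM. Compound 3 gives 9000000 nM in this assay. The change between them, (fluoro in place of nitro on an aromatic carbon), made a step of a 5.6-fold higher number from compound 1 to compound 3 (0.75 log units; beyond the scatter). For compound 2 the result in this assay is only a limit, not a number: > 10000000 nM. That value is the limit of > 10000000 nM in this assay, at which 1 of the 3 values shown sits.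

The change from compound 2 to compound 4 is fluoro in place of nitro on an aromatic carbon. For the measured compounds named here, it is the same kind of change as the one from compound 1 to compound 3, not the same: in the first pair the group sits ortho to a large group, in the second pair meta to a large group. Because the measured step of a 5.6-fold higher number from compound 1 to compound 3 (0.75 log units; beyond the scatter) went toward a higher number, and compound 2 already shows only a limit, compound 4 is expected to give 20000000 nM in this assay, most likely once more as a limit. The expected step for compound 4 is a step that the limit leaves unreadable from compound 2 to compound 4. The expected range for compound 4 runs from 8000000 nM to 80000000 nM.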

Compound 4, half-maximal inhibitory concentration: 6320000 nM
For compound 4 the middle estimate is 3.2-fold (0.50 log units) above the measured one, outside the stated range (below it).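

The swap of nitro for fluoro does not carry over as a fixed step from one core to the other in this assay, and the gap between the two results is larger than repeat measurements would explain: the same change on two cores in this assay, a 5.6-fold higher number (0.75 log units; beyond the scatter) from compound 1 to compound 3 and an at least 1.5-fold lower number (0.19 log units; that floor lies within the scatter) from compound 2 to compound 4, at least 8.9-fold (0.94 log units) apart, beyond the scatter of two such steps. On its own, the new result is an at least 1.5-fold lower number from compound 2 to compound 4 (0.19 log units; that floor lies within the scatter), so this floor cannot establish a real change in either direction. Compound 2 has only a limit, > 10000000 nM, which leaves the true size of this step unknown, and two pairs cannot show why the cores differ or how the swap would behave on a third core.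

From the compounds shown here alone, only nitro and fluoro appear at these two ring places, so it remains open whether the difference between the cores is peculiar to this pair of groups or would also appear with another group, such as an amine, a carboxylic acid or a methoxy group. Going by these compounds, it also remains open whether the same swap would separate the two cores in the same way at a concentration range where compound 2 gives a number rather than a limit.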